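The compounds below may be only part of what the source reports. "The series", "measured", "known", "first", "only" and "open" are said of these compounds alone.

Compound 1 `O=C(Nc1cccc(C(F)(F)F)c1)c1c(NO)cc(-c2ccccc2)oc1=O` gives 19000 nM in an ADME assay on Huh-7 cells (Homo sapiens) for cytotoxicity, with a stated time of 3 days; on this read-out lower numbers stand for higher toxicity in this test and higher numbers for lower toxicity in this test.
Compound 2 `O=C(Nc1ccccc1)c1c(NO)cc(-c2cccs2)oc1=O` gives > 20000 nM in this assay, a limit of the assay rather than a number.
Compound 3 `O=C(Nc1cccc(C(F)(F)F)c1)c1c(NO)cc(-c2cccs2)oc1=O` gives 11000 nM in this assay.

Compound 2 therefore stands at the limit of this assay, with no number of its own; it shares that place with the line described by the limit of > 20000 nM in this assay, at which 1 of the 3 values shown sits, at which one of the three values sits. The step to compound 4 `Nc1ccccc1NC(=O)c1c(NO)cc(-c2cccs2)oc1=O` is the change (amino in place of hydrogen on an aromatic carbon).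

Two measured steps surround this change without matching it. The step of a 1.7-fold lower number from compound 1 to compound 3 (0.24 log units; within the scatter) swaps one aromatic ring for another at the far end of the core and stays within the scatter. The step of an at least 1.8-fold lower number from compound 2 to compound 3 (0.25 log units; that floor lies within the scatter) adds a trifluoromethyl group to the same anilide ring that compound 4 alters, and its floor also lies within the scatter. Among the measured compounds shown here, neither step involves an amino group, so no measured step bears directly on it; both show that substituents on this scaffold moved this assay little. The expectation for compound 4 is accordingly no step beyond the scatter, a number no higher from compound 2 to compound 4 (the limit leaves the size open), with a fair chance that only a limit is reported again. Compound 4 is estimated at 20000 nM, between 8000 nM and 45000 nM.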

Compound 4, half-maximal cytotoxic concentration: > 20000 nM
Compound 4: only a limit was reported; the forecaster's own chance of this, stated with the estimate: 55%; the middle value lies on the limit itself.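

In this assay compound 2 and compound 4 each give a limit rather than a number, so no step can be read between them: the limit of > 20000 nM in this assay, at which 2 of the 4 values shown sit. The compounds shown leave open whether amino in place of hydrogen on this aromatic carbon changes the half-maximal cytotoxic concentration at all, and what number either compound would have.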